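The source may report more compounds than this note shows. Statements on the series, on what has been measured and on what is new or still open speak of the compounds shown alone.

Compounds measured so far:
- compound 1 `COc1cc2ncnc(Nc3ccc(NC(=O)c4ccccc4C)cc3)c2cc1OC`: 21000 nM
- compound 2 `COc1cc2ncnc(Nc3ccc(NC(=O)c4ccccc4F)cc3)c2cc1OC`: 11000 nM

Only these two numbers exist so far in a functional assay on MCF7 cells (Homo sapiens) for inhibition, read by MTT assay (on this read-out lower numbers stand for stronger inhibition and higher numbers for weaker inhibition), and they cannot be told apart: compound 2, at 11000 nM, lies within the usual scatter of compound 1.

The next compound to be tested is compound 3 `COc1cc2ncnc(Nc3ccc(NC(=O)c4ccc(F)cc4)cc3)c2cc1OC`. It has the same atoms as compound 2, joined differently, with 4-fluorophenyl in place of 2-fluorophenyl on a carbonyl carbon.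

Among the compounds with values here, only one measured step is available as a guide. It is a 1.9-fold lower number from compound 1 to compound 2 (0.28 log units; within the scatter), which puts fluoro in place of methyl on an aromatic carbon and stays within the scatter. Within the data shown here, that step is a different kind of change, since no measured pair swaps 2-fluorophenyl for 4-fluorophenyl. It does show that one change on this ring left the number in this assay unresolved, so no step beyond the scatter is expected here, in either direction.

The expected step is small: a 1.2-fold higher number from compound 2 to compound 3 (0.07 log units; within the scatter). For compound 3 the estimated value is 13000 nM, with an expected range from 5000 nM to 30000 nM.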

Compound 3, half-maximal inhibitory concentration: 27000 nM
Estimate against measurement, compound 3: 2.1-fold (0.32 log units) below; the measured number falls inside the stated range.
By their numbers in this assay, from the lowest: compounds 2, 1 and 3 (each within the scatter of the next, the first and the last beyond it).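

In this assay, within the data shown here, 4-fluorophenyl in place of 2-fluorophenyl on the carbonyl carbon gives a 2.5-fold higher number from compound 2 to compound 3 (0.39 log units; beyond the scatter), the only step in this small set that clears the scatter, and only modestly. The two compounds hold the same atoms, so this shows that the place of the fluorine on this ring can register in the number, which the earlier swap of methyl for fluoro could not show. 4-fluorophenyl in place of 2-methylphenyl gives a 1.3-fold higher number from compound 1 to compound 3 (0.11 log units; within the scatter), so that pair stays unresolved and the one separation rests on a single pair of compounds, with no measured evidence at hand to account for it.

The compounds shown leave open how plain phenyl, with neither fluoro nor methyl, would read on this carbonyl carbon, and whether 4-methylphenyl would differ from 2-methylphenyl as the two fluorophenyl groups differ from each other. They also leave open what an amine or a carboxylic acid on this ring would do to the number in this assay.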